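This account rests on a few compounds, and the source may have more. Where it says the series, first, only, none or still open, it means among the compounds named here.

In an ADME assay on GES1 cells (Homo sapiens) for inhibition, read by MTT assay, with a stated time of 72 h (on this read-out lower numbers stand for stronger inhibition and higher numbers for weaker inhibition), compound 1 `CCCCCc1c(C)nc2nc(SCc3ccc(Cl)cc3)nn2c1Nc1cc(-c2ccccc2)[nH]n1` stands at > 50000 nM, which is a limit of the assay. Within the data shown here, compound 2 `Cc1cc(Nc2cc(-c3ccccc3)[nH]n2)n2nc(SCc3ccc(Cl)cc3)nc2n1` gives 31800 nM, the only actual number so far. Compound 3 `Cc1nc2nc(SCc3ccc(Cl)cc3)nn2c(Nc2cc(-c3ccccc3)[nH]n2)c1C` differs from it by methyl in place of hydrogen on an aromatic carbon, with methyl in place of hydrogen on an aromatic carbon. Among the measured compounds shown here, the one measured step bearing on this, an at least 1.5-fold lower number from compound 1 to compound 2 (0.19 log units; that floor lies within the scatter), has hydrogen in place of pentyl on that same carbon, and it rests on (the limit of > 50000 nM in this assay, at which 1 of the 2 values shown sits). Its floor lies within the scatter, so no step beyond the scatter is expected, and the estimated step is a 1.1-fold higher number from compound 2 to compound 3 (0.04 log units; within the scatter). Compound 3 is expected at 35000 nM, with an estimated range from 18000 nM to 60000 nM.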

Compound 3, half-maximal inhibitory concentration: 47200 nM
Beside the measured number, compound 3's estimate is 1.3-fold (0.13 log units) below it, within the range that was stated.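

In this assay, methyl in place of hydrogen on this aromatic carbon gives a 1.5-fold higher number from compound 2 to compound 3 (0.17 log units; within the scatter), so a single added carbon here produces no step beyond the scatter. With pentyl on the same carbon replaced by methyl, the read-out gives an at least 1.0-fold lower number from compound 1 to compound 3 (0.02 log units; that floor lies within the scatter), and this floor also leaves no step beyond the scatter shown. That step has only a floor, since compound 1 stands at a limit of the assay: the limit of > 50000 nM in this assay, at which 1 of the 3 values shown sits.

On these data alone, how far compound 1 truly lies from compound 3 remains open. So does whether an amine, a carboxylic acid or a phenyl ring on this carbon would move the read-out.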